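The compounds below may be only part of what the source reports. "The series", "measured", "known", "first", "only" and "open" are said of these compounds alone.

- compound 1 `COc1ccc(-c2ccc3nnc([C@@H](C)c4ccc5ncccc5c4)n3n2)cc1F` gives 10900 nM
- compound 2 `C[C@@H](c1ccc2ncccc2c1)c1nnc2ccc(-c3ccccc3C#N)nn12` gives 213000 nM
- compound 3 `CNC(=O)c1ccc(-c2ccc3nnc([C@@H](C)c4ccc5ncccc5c4)n3n2)cc1` gives 11000 nM
- compound 4 `CCS(=O)(=O)c1ccc(-c2ccc3nnc([C@@H](C)c4ccc5ncccc5c4)n3n2)cc1` is not yet measured

In a physicochemical assay for solubility, measured as kinetic solubility, at pH 6.5 (a lower number here means a less soluble compound, a higher number a more soluble compound), compound 3 gives 11000 nM and so sits level with compound 1 and well short of compound 2. Compound 4 puts ethylsulfonyl in place of methylcarbamoyl on an aromatic carbon. Swapping 3-fluoro-4-methoxyphenyl for 4-(methylcarbamoyl)phenyl gave a step within the scatter (a 1.0-fold higher number from compound 1 to compound 3 (0.00 log units; within the scatter)). The large steps (a 20-fold higher number from compound 1 to compound 2 (1.29 log units; beyond the scatter) and a 19-fold lower number from compound 2 to compound 3 (1.29 log units; beyond the scatter)) both involve the 2-cyanophenyl group of compound 2, which compound 4 lacks. No step beyond the scatter is therefore expected (a 1.1-fold lower number from compound 3 to compound 4 (0.04 log units; within the scatter)). Compound 4 is estimated at 10000 nM with an expected range from 3000 nM to 35000 nM around that figure.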

Compound 4, solubility: 136000 nM
The estimate for compound 4 lay 14-fold (1.13 log units) below the measured number; measured number outside the range, above it.
By their numbers in this assay, from the lowest: compounds 1 and 3 (each within the scatter of the next); then compounds 4 and 2 (each within the scatter of the next).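

In this assay, ethylsulfonyl in place of methylcarbamoyl on the same aromatic carbon gives a 12-fold higher number from compound 3 to compound 4 (1.09 log units; beyond the scatter) and shows that this position responds strongly to the group it carries, even with the rest of the molecule unchanged. A para group on this phenyl ring can therefore shift the number sharply without any 2-cyanophenyl group being present. No supporting data explain the step.

As far as these compounds go, whether it comes from the sulfonyl group or from its ethyl chain remains open. Methylsulfonyl or a sulfonamide at this position would help separate the two.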